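The source may report more compounds than this note shows. Statements on the series, on what has been measured and on what is new or still open speak of the compounds shown alone.

Working notes on the series. The shared core of compound 1 `COc1cc(NC(C)CCCNC(=O)Nc2ccc(F)cc2)c2ncccc2c1` carries a urea closed by a 4-fluorophenyl group, and in a functional assay on MCF7 cells (Homo sapiens) for inhibition, read by MTT assay, with a stated time of 72 h (on this read-out lower numbers stand for stronger inhibition and higher numbers for weaker inhibition), compound 1 gives 26000 nM. Compound 2 `COc1cc(NC(C)CCCNC(=O)NNC(=O)Nc2ccc(F)cc2)c2ncccc2c1` inserts a ((4-fluorophenyl)carbamoyl)amino unit, and compound 2 gives 310 nM, a change of an 84-fold lower number from compound 1 to compound 2 (1.92 log units; beyond the scatter). Compound 3 `COc1cc(NC(C)CCCNC(=O)Nc2cccc(F)c2)c2ncccc2c1` moves the fluoro to give 3-fluorophenyl, and compound 3 gives 18000 nM. Compound 3 stands second highest of the three numbers: its nearest neighbour is compound 1, the step of a 1.4-fold lower number from compound 1 to compound 3 (0.16 log units; within the scatter); its furthest is compound 2, the step of a 58-fold higher number from compound 2 to compound 3 (1.76 log units; beyond the scatter).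

Compound 4 `COc1cc(NC(C)CCCNC(=O)Nc2cccc(C(F)(F)F)c2)c2ncccc2c1` differs from compound 3 by trifluoromethyl in place of fluoro on an aromatic carbon. Going by the values given here, the only measured step touching the phenyl ring is a 1.4-fold lower number from compound 1 to compound 3 (0.16 log units; within the scatter), which stayed within the scatter; no measured step exchanges fluoro for trifluoromethyl, so there is no direct precedent. The expectation for compound 4 is therefore a step of a 1.2-fold lower number from compound 3 to compound 4 (0.08 log units; within the scatter), no more than the scatter. Compound 4 is estimated at 15000 nM, with a range of 6000 nM to 40000 nM.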

Compound 4, half-maximal inhibitory concentration: 3300 nM
Estimate against measurement, compound 4: 4.5-fold (0.66 log units) above; the whole stated range lies above it.
By their numbers in this assay, from the lowest: compound 2; then compound 4; then compounds 3 and 1 (each within the scatter of the next).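

At this aromatic carbon the identity of the substituent matters in this assay: trifluoromethyl in place of fluoro gives a step beyond the scatter (a 5.5-fold lower number from compound 3 to compound 4 (0.74 log units; beyond the scatter)), whereas moving the fluoro on the phenyl ring had stayed within it (a 1.4-fold lower number from compound 1 to compound 3 (0.16 log units; within the scatter)). The 3-(trifluoromethyl)phenyl urea also separates from the 4-fluorophenyl urea (a 7.9-fold lower number from compound 1 to compound 4 (0.90 log units; beyond the scatter)), but it does not reach the compound carrying the ((4-fluorophenyl)carbamoyl)amino unit (an 11-fold higher number from compound 2 to compound 4 (1.03 log units; beyond the scatter)). Nothing at hand accounts for the step at this position.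

As far as these compounds go, it remains open whether trifluoromethyl on the phenyl ring would give a comparable step in the setting of compound 2. From the compounds shown here alone, it is also open whether a nitrile or a carboxylic acid at this carbon would track with trifluoromethyl or with fluoro.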